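Methylsulfonyl on the Amide Nitrogen of Compound 1

The compounds below may be only part of what the source reports. "The series", "measured", "known", "first", "only" and "open" are said of these compounds alone.

Compound 1 `N#Cc1ccc(-c2cc(-c3ccc(C(N)=O)cc3)cc(-c3ccco3)n2)cc1` gives 3000 nM in an assay on cells for binding affinity to Myc proto-oncogene protein (Homo sapiens); on this read-out higher numbers stand for weaker inhibition and lower numbers for stronger inhibition. Among the three measured compounds it holds the second highest number; its nearest neighbour is compound 3 `NC(=O)c1ccc(-c2cc(-c3ccc(-c4cnco4)cc3)nc(-c3ccco3)c2)cc1`, which gives 2500 nM, a change of a 1.2-fold lower number from compound 1 to compound 3 (0.08 log units; within the scatter); the furthest is compound 2 `Cn1nncc1-c1cc(-c2ccc(C(N)=O)cc2)cc(-c2ccc(C#N)cc2)n1`, which gives 40000 nM, a change of a 13-fold higher number from compound 1 to compound 2 (1.12 log units; beyond the scatter). Compound 4 `CS(=O)(=O)NC(=O)c1ccc(-c2cc(-c3ccc(C#N)cc3)nc(-c3ccco3)c2)cc1` differs from compound 1 by methylsulfonyl in place of hydrogen on an amide-type nitrogen, turning the carbamoyl into a (methylsulfonyl)carbamoyl group. Neither measured step touches this position: the step from compound 1 to compound 3 alters the cyano-bearing ring and stays within the scatter, while the step from compound 1 to compound 2 replaces the furan-2-yl group and is large. Among the compounds with values here, the carbamoyl group itself has no measured precedent in this set, so no directional pull can be read from the data, and the step is expected to be a 1.3-fold higher number from compound 1 to compound 4 (0.12 log units; within the scatter), within the scatter. Compound 4 is therefore estimated at 4000 nM, with a range from 1500 nM to 12000 nM.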

Compound 4, half-maximal inhibitory concentration: 10000 nM
Beside the measured number, compound 4's estimate is 2.5-fold (0.40 log units) below it; measured number inside the range.
By their numbers in this assay, from the lowest: compounds 3 and 1 (each within the scatter of the next); then compound 4; then compound 2.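

In this assay, the amide-type nitrogen of compound 1 proves responsive to substitution: methylsulfonyl in place of hydrogen gives a 3.3-fold higher number from compound 1 to compound 4 (0.52 log units; beyond the scatter), a modest shift towards weaker inhibition that lies beyond the scatter. Within the data shown here, this is the first reading at the carbamoyl group, since the earlier steps changed only the cyano group and the furan-2-yl group. The change costs less than replacing the furan-2-yl group with 1-methyl-1H-1,2,3-triazol-5-yl, which gives a 13-fold higher number from compound 1 to compound 2 (1.12 log units; beyond the scatter).

On these data alone, whether an acetyl or a methyl group on this nitrogen, or a carboxylic acid in place of the carbamoyl, would move the number in the same direction remains open. Nothing available accounts for the rise seen with methylsulfonyl.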